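A few compounds are considered here, and "the series" means these few. Any claim that something is new, unique, unknown or untested is made for them only; others in the source may bear on it.

Measured compounds:
- compound 1, `CC(=O)Nc1ccc(CN2CCC=C(CCC(=O)NO)C2=O)cc1`: "not determined" (no result reported)
- compound 2, `O=C(CCC1=CCCN(CCCc2ccc3ccccc3c2)C1=O)NO`: 460 nM
- compound 3, `O=C(CCC1=CCCN(CCCCc2cccc3ccccc23)C1=O)NO`: 1820 nM

Compound 1 has no single number in a functional assay on ACHN cells (Homo sapiens) for inhibition, read by sulforhodamine B assay; a higher number here means a weaker inhibitor of growth, a lower number a stronger inhibitor of growth; on the numbers shown it stands nowhere, and the only measured anchors are the two hydroxamic acids with a naphthalene-bearing chain on the ring nitrogen. In this assay, among the measured compounds shown here, compound 2 gives 460 nM, while compound 3 gives 1820 nM; no step between them is set out, so their two values are simply what they show.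

Compound 4, `O=C(CCC1=CCCN(Cc2ccc(NC(=O)c3ccccc3)cc2)C1=O)NO`, follows from compound 1 by a single change on the acetamido group: phenyl in place of methyl on a carbonyl carbon. The cap on the ring nitrogen thus grows from acetamido to benzamido, while the hydroxamic acid and the shared core stay untouched.

For the measured compounds named here, with compound 1 unmeasured, no step from it to compound 4 can be placed on a scale. In this assay the step is expected to be small, within the usual scatter or only modestly beyond it, and if it goes anywhere it is expected to go toward a lower number, that is, stronger growth inhibition. Compound 4 is estimated at 800 nM, with a range from 200 nM to 4000 nM, because compound 2 gives 460 nM and compound 3 gives 1820 nM for caps of comparable bulk.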

Compound 4, concentration for 50% growth inhibition: > 10000 nM
Compound 4: no number, only a limit (the forecaster's own chance of this, stated with the estimate: 10%); middle value at least 12-fold (1.09 log units) away from the limit.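

In this assay compound 4 gives > 10000 nM, which is a limit of the assay and not a number. Among the compounds shown here, compound 1 has no number either, so no step from compound 1 to compound 4 can be read. The compounds shown leave open whether, and how far, going from acetamido to benzamido shifts growth inhibition.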